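A Larger Hydroxylated Group on a Weak Amide

The compounds below may be only part of what the source reports. "The series", "measured", "known", "first", "only" and "open" are said of these compounds alone.

Among the measured compounds shown here, compound 2 `CCn1c(C(=O)NCCCO)ccc1C(CC)(CC)c1ccc(OCS(=O)(=O)c2ccccc2)c(C)c1` gives 26600 nM in a functional assay on BXPC-3 cells (Homo sapiens) for antiproliferative activity, read by MTT assay, with a stated time of 24 h (a lower number here means a stronger inhibitor, a higher number a weaker inhibitor), as the only actual number so far. Compound 1 `CCn1c(C(=O)NCCNC(=O)OC(C)(C)C)ccc1C(CC)(CC)c1ccc(OCS(=O)(=O)c2ccccc2)c(C)c1` stands at > 50000 nM as a limit of the assay and not a number. For the measured compounds named here, the single measured step is an at least 1.8-fold lower number from compound 1 to compound 2 (0.27 log units; that floor lies within the scatter) and so sets no firm size for what follows. Going by the values given here, compound 3 `CCn1c(C(=O)N[C@H](CO)CCCO)ccc1C(CC)(CC)c1ccc(OCS(=O)(=O)c2ccccc2)c(C)c1` carries a group of 7 heavy atoms (5 carbon, 2 oxygen; no ring) in place of a group of 4 heavy atoms (3 carbon, 1 oxygen; no ring), on an amide-type nitrogen as its one change from compound 2. With so little to go on, the expected step is a 1.1-fold higher number from compound 2 to compound 3 (0.05 log units; within the scatter) in this assay and so none beyond the scatter. Compound 3 is estimated at 30000 nM with an expected range from 12000 nM to 75000 nM in this test.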

Compound 3, half-maximal inhibitory concentration: > 50000 nM
Compound 3 gave a limit, no number (the forecaster's own chance of this, stated with the estimate: 35%); middle value at least 1.6-fold (0.22 log units) away from the limit.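

The larger group on the amide-type nitrogen of compound 3 brings no gain in this test, with an at least 1.8-fold higher number from compound 2 to compound 3 (0.27 log units; that floor lies within the scatter). Among the compounds shown here, the value of compound 3 is a limit of the assay and not a number, so compound 2 remains the only compound here with a measured value. The step between compound 1 and compound 3 cannot be read, and the limit now covers most of the set: the limit of > 50000 nM in this assay, at which 2 of the 3 values shown sit.

On these data alone, whether an amine, a carboxylic acid or a shorter chain on this nitrogen would improve on compound 2, at 26600 nM, stays open. As far as these compounds go, how the mirror-image form of compound 3 would read also stays open.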